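The source may report more compounds than this note shows. Statements on the series, on what has been measured and on what is new or still open speak of the compounds shown alone.

Measured compounds:
compound 1, `Cc1occc1-c1nnc2n1NC(c1ccco1)S2`: 16.4%
compound 2, `Cc1occc1-c1nnc2n1NC(c1ccc([N+](=O)[O-])o1)S2`: 15.6%

In a functional assay on the whole organism (strain Wistar Albino) for inhibition, with Rattus norvegicus as the target, read by paw edema, with a stated time of 1 h, at a dose of 20 mg/kg (a higher number here means more inhibition at the dose given (going by the name of the read-out), a lower number less inhibition), compound 1 gives 16.4%. Of the two numbers shown, the one for compound 1 is the larger, but the step of a number 0.8 percentage points lower from compound 1 to compound 2 (within the scatter) lies within the scatter, so the two measured compounds cannot be told apart on this evidence. Within the data shown here, that single measured step, a nitro in place of hydrogen on an aromatic carbon, is the only comparison available.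

Compound 3, `Cc1occc1-c1nnc2n1NC(c1ccc[nH]1)S2`, has not yet been measured. It differs from compound 1 by 1H-pyrrol-2-yl in place of furan-2-yl on a saturated ring carbon. The step from compound 1 to compound 2 touches the furan-2-yl ring only at one aromatic carbon and does not exchange the ring itself, so it bears on this change only loosely; it was within the scatter. Among the measured compounds shown here, no measured step addresses a 1H-pyrrol-2-yl in place of furan-2-yl on a saturated ring carbon. Compound 3 is therefore expected to show a step of a number 0.4 percentage points lower from compound 1 to compound 3 (within the scatter) from compound 1, that is, none beyond the scatter. For compound 3 the estimate in this assay is 16%, with a range from 7% to 27%.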

Compound 3, a percentage reported as inhibition, in the whole organism at one dose (the size of the read-out at that dose, not a potency): 13.7%
For compound 3 the middle estimate is 2.3 percentage points above the measured one, and the stated range covers the measured number.
By their numbers in this assay, from the lowest: compounds 3, 2 and 1 (each within the scatter of the next).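

In this assay, the exchange of furan-2-yl for 1H-pyrrol-2-yl on the saturated ring carbon gives a number 2.7 percentage points lower from compound 1 to compound 3 (within the scatter) and so, unlike the earlier nitro step, replaces the ring itself rather than one of its hydrogens. The entering ring carries a hydrogen-bond donor where the leaving ring carries a hydrogen-bond acceptor, yet this exchange does not separate the two compounds at this dose and time, just as a number 0.8 percentage points lower from compound 1 to compound 2 (within the scatter) did not separate the earlier pair. No measurement shown here offers an explanation for how closely these numbers agree. All three compounds therefore carry a five-membered aromatic ring at this position, and none of the changes so far can be distinguished from repeated measurement. As far as these compounds go, it remains open whether a phenyl ring or a longer alkyl chain at the saturated ring carbon would give a number beyond the scatter, and whether an amine or a carboxylic acid on the five-membered aromatic ring, in place of the nitro group, would do so.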